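The source may report more compounds than this note shows. Statements on the series, on what has been measured and on what is new or still open speak of the compounds shown alone.

Compound 3 `O=C(O)c1cc2cc(-c3ccccc3)n(O)c2cc1C(=O)O` is the only one of the three measured compounds that returns a number in an assay on isolated protein for inhibition of Amine oxidase [flavin-containing] B (Homo sapiens), read by fluorescence and spectrophotometry, with a stated time of 20 min; on this read-out higher numbers stand for weaker inhibition and lower numbers for stronger inhibition: compound 3 gives 56200 nM. The two companions carry a different core. For compound 1 `COn1c(-c2ccccc2)c(CO)c2cc(C#N)c(C#N)cc21` the reading in this assay is a limit, > 100000 nM. Compound 2 `COn1c(-c2ccc(C)cc2)c(CO)c2cc(C#N)c(C#N)cc21` differs from compound 1 by a methyl in place of hydrogen on an aromatic carbon. In this assay the reading for compound 2 is likewise a limit, > 100000 nM. The step from compound 1 to compound 2 is therefore a step that the two limits leave unreadable from compound 1 to compound 2, and this rests on (the limit of > 100000 nM in this assay, at which 2 of the 3 values shown sit).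

Compound 4 `COc1ccc(-c2cc3cc(C(=O)O)c(C(=O)O)cc3n2O)cc1` differs from compound 3 by methoxy in place of hydrogen on an aromatic carbon. Going by the values given here, the only measured step that touches a change of this kind, a small group added to the phenyl on an aromatic carbon, is the one from compound 1 to compound 2, and its size cannot be read. Among the compounds with values here, no measured step in this assay therefore points to a change in either direction, and the expected step from compound 3 to compound 4 is a 1.1-fold lower number from compound 3 to compound 4 (0.05 log units; within the scatter), within the scatter. The estimate for compound 4 in this assay is 50000 nM, with a range from 15000 nM to 150000 nM.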

Compound 4, half-maximal inhibitory concentration: > 100000 nM
Compound 4: no number, only a limit; the forecaster's own chance of this, stated with the estimate: 30%; at least 2.0-fold (0.30 log units) between middle value and limit.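

On the core of compound 3, the change from phenyl to 4-methoxyphenyl gives an at least 1.7-fold higher number from compound 3 to compound 4 (0.25 log units; that floor lies within the scatter). This is a floor rather than a full size, yet it is more than the step between compound 1 and compound 2 could offer, and it gives no sign that methoxy at this place strengthens inhibition in this assay. Compound 4 reads only as a limit, which leaves compound 3 as the sole compound with a number: the limit of > 100000 nM in this assay, at which 3 of the 4 values shown sit.

The compounds shown leave open what an amine or a chlorine atom at this same place on the phenyl would do, and whether any group there would bring the number down from that of compound 3. They also leave open how this core would read with an amide in place of either carboxylic acid.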